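Methoxy walk on the aryl ring: compounds 1 to 4

This account rests on a few compounds, and the source may have more. Where it says the series, first, only, none or still open, it means among the compounds named here.

Compound 1 `COc1ccccc1-c1nc2cc(F)ccc2o1` gives 360 nM in a functional assay on MCF7 cells (Homo sapiens) for inhibition; on this read-out higher numbers stand for weaker inhibition and lower numbers for stronger inhibition. Compound 2 `COc1cccc(OC)c1-c1nc2cc(F)ccc2o1` differs from it by methoxy in place of hydrogen on an aromatic carbon and gives 58100 nM in this assay, a step of a 160-fold higher number from compound 1 to compound 2 (2.21 log units; beyond the scatter). Compound 3 `COc1cc(OC)cc(-c2nc3cc(F)ccc3s2)c1` rests on a different core; the difference between the two cores is not broken down here. In this assay compound 3 gives 1230 nM. Compound 4 `COc1cc(-c2nc3cc(F)ccc3s2)cc(OC)c1OC` differs from compound 3 by methoxy in place of hydrogen on an aromatic carbon. This is the same kind of change as from compound 1 to compound 2, but not the same: there the entering methoxy sat ortho to a large group and meta to a methoxy group, here it sits ortho to two methoxy groups and para to a large group. Within the data shown here, compound 4 is expected to show a step of a 4.1-fold higher number from compound 3 to compound 4 (0.61 log units; beyond the scatter), smaller than the earlier one, because the only comparison available, a 160-fold higher number from compound 1 to compound 2 (2.21 log units; beyond the scatter), was made at a different place. The estimate for compound 4 is 5000 nM, within 1200 nM to 25000 nM.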

Compound 4, half-maximal inhibitory concentration: 1.9 nM
Compound 4: middle estimate off by 2600-fold (3.42 log units), on the high side; measured number outside the range, below it.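

In this assay the new step is a 650-fold lower number from compound 3 to compound 4 (2.81 log units; beyond the scatter), for methoxy in place of hydrogen on an aromatic carbon, here ortho to two methoxy groups and para to a large group. Neither the size nor the direction of this change carries over between the two cores in this series: the same change on two cores in this assay, a 160-fold higher number (2.21 log units; beyond the scatter) from compound 1 to compound 2 and a 650-fold lower number (2.81 log units; beyond the scatter) from compound 3 to compound 4, 100000-fold (5.02 log units) apart, beyond the scatter of two such steps The two steps differ both in the core and in the place of the entering methoxy, and these pairs cannot separate the two.

The compounds shown leave open how the core of compound 1 responds to methoxy at the place filled in compound 4. They also leave open whether a hydroxyl, an ethoxy group or a fluorine at that place would match methoxy on the core of compound 4.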